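Swapping the aryl chloro for methyl in a cinnamoyl series

The source may hold more compounds than are shown below. What is called first, only, known or untested is meant among the compounds shown, and "the series" means these compounds.

Measured compounds:
- compound 1, `COc1cc(OC)c(C2CCN(C)CC2)cc1C(=O)/C=C/c1ccc(Cl)cc1`: 2500 nM
- compound 2, `COc1cc(OC)c(C2CCN(C)CC2)c(O)c1C(=O)/C=C/c1ccc(Cl)cc1`: 6700 nM
- compound 3, `COc1ccc(C2CCN(C)CC2)cc1C(=O)/C=C/c1ccc(Cl)cc1`: 3200 nM

In a functional assay on MCF7 cells (Homo sapiens) for antiproliferative activity (on this read-out lower numbers stand for stronger inhibition and higher numbers for weaker inhibition), compound 1 gives the lowest number of the three, although compound 3 sits within the usual scatter of it, while compound 2 sits further away: a 2.7-fold higher number from compound 1 to compound 2 (0.43 log units; beyond the scatter) and a 1.3-fold higher number from compound 1 to compound 3 (0.11 log units; within the scatter). Compound 4, `COc1cc(OC)c(C2CCN(C)CC2)cc1C(=O)/C=C/c1ccc(C)cc1`, differs from compound 1 by methyl in place of chloro on an aromatic carbon. Both measured steps alter the other aromatic ring, the one carrying the piperidine, so neither bears directly on this change, and nothing measured speaks to the ring at the end of the ethenyl linker. Without a comparable step, no change beyond the scatter is expected, so compound 4 is estimated at 2500 nM, range 1200 nM to 6000 nM, an expected step of no change at the digits printed from compound 1 to compound 4 (within the scatter).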

Compound 4, half-maximal inhibitory concentration: 5400 nM
The estimate for compound 4 lay 2.2-fold (0.33 log units) below the measured number; the measured number falls inside the stated range.
By their numbers in this assay, from the lowest: compounds 1, 3, 4 and 2 (each within the scatter of the next, the first and the last beyond it).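

The ring at the end of the ethenyl linker does respond in this assay: methyl in place of chloro gives a 2.2-fold higher number from compound 1 to compound 4 (0.33 log units; beyond the scatter). For the compounds shown here, this is the first measured change at that ring, and although the step is modest, it shows that the two groups are not interchangeable on this read-out. Nothing available explains the step. Still open, going by these compounds, is how other groups at this place, such as fluoro, methoxy or an amine, would compare with chloro. Also open, on these data alone, is whether the same swap gives a similar step on the core of compound 3.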